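The source may report more compounds than this note shows. Statements on the series, on what has been measured and on what is new or still open speak of the compounds shown alone.

Measured compounds in an assay on HEK293 cells for binding affinity to Gonadotropin-releasing hormone receptor (Homo sapiens); a higher number here means a weaker inhibitor, a lower number a stronger inhibitor:
- compound 1, `COc1cccc(-c2c(C)n(Cc3c(F)cccc3F)c(=O)n([C@@H](C)CNCc3ccccc3)c2=O)c1`: 370 nM
- compound 2, `COc1cccc(-c2c(C)n(Cc3c(F)cccc3F)c(=O)n([C@H](C)CNCC(C)C)c2=O)c1`: 190 nM
- compound 3, `COc1cccc(-c2c(C)n(Cc3c(F)cccc3F)c(=O)n([C@H](C)CNCc3ccccc3F)c2=O)c1`: 90 nM

Among these three, compound 3 gives the lowest number in this assay, and both of its separations are beyond the scatter: a 2.1-fold lower number from compound 2 to compound 3 (0.32 log units; beyond the scatter) and a 4.1-fold lower number from compound 1 to compound 3 (0.61 log units; beyond the scatter). Compound 4, `COc1cccc(-c2c(C)n(Cc3c(F)cccc3F)c(=O)n([C@H](C)CNCc3cccc(F)c3)c2=O)c1`, has not yet been measured there. It differs from compound 3 only in where the fluorine sits on the ring that hangs from the amine: 3-fluorophenyl in place of 2-fluorophenyl on a saturated chain carbon bound to an amine nitrogen. The same atoms are present, joined differently.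

Among the compounds with values here, two measured steps touch this part of the molecule. From compound 2 to compound 3 the isopropyl became 2-fluorophenyl, and from compound 1 to compound 3 a plain benzyl gained a fluorine. Within the data shown here, neither step moves a fluorine around the ring, so there is no direct precedent for the change to compound 4. With the ring and its fluorine kept, only relocated, the expectation for compound 4 is a small step, within the scatter, in either direction: a 1.3-fold higher number from compound 3 to compound 4 (0.12 log units; within the scatter). The estimate for compound 4 in this assay is 120 nM, with a range from 45 nM to 320 nM.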

Compound 4, inhibition constant: 85 nM
Compound 4: middle estimate off by 1.4-fold (0.15 log units), on the high side, within the range that was stated.
By their numbers in this assay, from the lowest: compounds 4 and 3 (each within the scatter of the next); then compounds 2 and 1 (each within the scatter of the next).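

Moving the fluorine on this ring makes no measurable difference in this assay (a 1.1-fold lower number from compound 3 to compound 4 (0.02 log units; within the scatter)), so at this place on the saturated chain carbon bound to an amine nitrogen, 2-fluorophenyl and 3-fluorophenyl cannot be told apart. The gain seen with the fluorinated ring therefore does not rest on the 2-fluorophenyl arrangement alone, since the 3-fluorophenyl compound also gives a lower number than the isopropyl compound (a 2.2-fold lower number from compound 2 to compound 4 (0.35 log units; beyond the scatter)) and the plain benzyl compound (a 4.4-fold lower number from compound 1 to compound 4 (0.64 log units; beyond the scatter)). Nothing measured here accounts for the two fluorine placements matching.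

The compounds shown leave open whether the ring tolerates a different group in place of the fluorine, such as a chlorine or a methoxy group. They also leave open how a pyridine ring would compare with these fluorophenyl rings.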